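Second ring methyl on compound 2

The compounds below may be only part of what the source reports. "The series", "measured", "known", "first", "only" and "open" are said of these compounds alone.

In a functional assay on Jurkat cells (Homo sapiens) (on this read-out higher numbers stand for weaker inhibition and lower numbers for stronger inhibition), compound 1 `C[C@H](NC(=O)C(=O)NCCC1CCCC1)C(=O)N[C@@H](CC(=O)O)C(=O)COc1c(F)c(F)cc(F)c1F` gives 11 nM, compound 2 `Cc1cccc(CNC(=O)C(=O)N[C@@H](C)C(=O)N[C@@H](CC(=O)O)C(=O)COc2c(F)c(F)cc(F)c2F)c1` gives 127 nM and compound 3 `Cc1cccc(CNC(=O)C(=O)N[C@@H](C)C(=O)N[C@@H](CC(=O)O)C(=O)COc2c(F)c(F)cc(F)c2F)c1C` gives 102 nM. Compound 2 stands level with compound 3, and both lie far from compound 1: a 12-fold higher number from compound 1 to compound 2 (1.06 log units; beyond the scatter), and a 9.3-fold higher number from compound 1 to compound 3 (0.97 log units; beyond the scatter). Compound 4 `Cc1ccc(CNC(=O)C(=O)N[C@@H](C)C(=O)N[C@@H](CC(=O)O)C(=O)COc2c(F)c(F)cc(F)c2F)cc1C` differs from compound 2 by methyl in place of hydrogen on an aromatic carbon. Among the compounds with values here, the nearest precedent is the same kind of change at another ring position, a 1.2-fold lower number from compound 2 to compound 3 (0.10 log units; within the scatter). The two larger steps replace the whole cyclopentylmethyl group and say little here. No step beyond the scatter is therefore expected in this assay. The expected step is a 1.2-fold lower number from compound 2 to compound 4 (0.06 log units; within the scatter). Compound 4 is estimated at 110 nM, with a range of 55 nM to 220 nM.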

Compound 4, half-maximal inhibitory concentration: > 10000 nM
Compound 4: no number, only a limit (the forecaster's own chance of this, stated with the estimate: 1%); at least 90-fold (1.95 log units) between middle value and limit.
By their numbers in this assay, from the lowest: compound 1; then compounds 3 and 2 (each within the scatter of the next). At a limit, above all of these: compound 4.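

The second methyl is not neutral at this position, para to a large group and ortho to a methyl group (an at least 78-fold higher number from compound 2 to compound 4 (1.89 log units; beyond the scatter)), although the same kind of addition in compound 3 stays within the scatter (a 1.2-fold lower number from compound 2 to compound 3 (0.10 log units; within the scatter)). Where the second methyl sits therefore decides the read-out for this pair (an at least 98-fold higher number from compound 3 to compound 4 (1.99 log units; beyond the scatter)), and the gap to the cyclopentylmethyl compound widens (an at least 900-fold higher number from compound 1 to compound 4 (2.95 log units; beyond the scatter)). In this assay compound 4 gives > 10000 nM, which is a limit and not a number: the limit of > 10000 nM in this assay, at which 1 of the 4 values shown sits.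

From the compounds shown here alone, whether 4-methylbenzyl alone shows the same loss stays open. So does the effect of fluorine, methoxy or ethyl at this position.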